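The compounds below may be only part of what the source reports. "The series", "measured", "known", "first", "only" and "open" are said of these compounds alone.

Measured so far:
- compound 1 `CC(C)(C)n1cc2c(n1)C(=O)CC1(CCN(C(=O)c3cc(-c4ccccc4Cl)nc4ccccc34)CC1)O2`: 2180 nM
- compound 2 `CC(C)(C)n1cc2c(n1)C(=O)CC1(CCN(C(=O)c3cc(-c4ccc(Br)cc4)nc4ccccc34)CC1)O2`: 9300 nM

In a functional assay on A549 cells (Homo sapiens) for inhibition, read by MTT assay, with a stated time of 72 h (a higher number here means a weaker inhibitor, a lower number a stronger inhibitor), compound 2 gives 9300 nM, the higher of the two numbers, which makes it the weaker inhibitor of the pair.

Next in the series is compound 3 `COc1ccc(-c2cc(C(=O)N3CCC4(CC3)CC(=O)c3nn(C(C)(C)C)cc3O4)c3ccccc3n2)cc1OC`, which has 3,4-dimethoxyphenyl in place of 4-bromophenyl on an aromatic carbon, next to the ring nitrogen: 3,4-dimethoxyphenyl in place of 4-bromophenyl on an aromatic carbon.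

Within the data shown here, only one measured step bears on this change: a 4.3-fold higher number from compound 1 to compound 2 (0.63 log units; beyond the scatter). It swaps one substituted phenyl for another on the same carbon and is modest, though beyond the scatter. Among the measured compounds shown here, no measured compound carries a methoxy group, so the direction rests on thin evidence. With compound 1 at 2180 nM as the only other reference, a modest move towards a lower number is expected in this assay, and a result within the scatter of compound 2 would be no surprise. The estimated step is a 1.9-fold lower number from compound 2 to compound 3 (0.27 log units; within the scatter). For compound 3 the expected value is 5000 nM, with an estimated range of 1800 nM to 14000 nM.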

Compound 3, half-maximal inhibitory concentration: 2030 nM
Beside the measured number, compound 3's estimate is 2.5-fold (0.39 log units) above it; the range from low to high includes it.
By their numbers in this assay, from the lowest: compounds 3 and 1 (each within the scatter of the next); then compound 2.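

In this assay, the 3,4-dimethoxyphenyl group on the aromatic carbon next to the ring nitrogen gives a 4.6-fold lower number from compound 2 to compound 3 (0.66 log units; beyond the scatter), so this position responds to a change of aryl group in both directions, not only to the loss seen earlier with 4-bromophenyl. The step of a 1.1-fold lower number from compound 1 to compound 3 (0.03 log units; within the scatter) shows that 2-chlorophenyl and 3,4-dimethoxyphenyl cannot be told apart here, even though they differ in size and the entering group carries 2 hydrogen-bond acceptors, so among the three compounds only the 4-bromophenyl of compound 2 stands apart. No measured evidence is available to explain these differences.

The compounds shown do not separate the identity of the halogen from its place on the phenyl ring, a question that unsubstituted phenyl, 2-bromophenyl and 4-chlorophenyl would address, nor do they show which of the two methoxy groups matters, as 3-methoxyphenyl and 4-methoxyphenyl would. As far as these compounds go, it also remains open how this position would take an aryl group bearing an amine or a carboxylic acid.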